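This account rests on a few compounds, and the source may have more. Where it says the series, first, only, none or still open, it means among the compounds named here.

Measured so far in an assay on U2OS cells for activation of nuclear factor erythroid 2-related factor 2 (Homo sapiens), read by chemiluminescence, with a stated time of 6 h; a lower number here means that less compound is needed, a higher number that more compound is needed for the effect:
compound 1, `COc1ccc(OS(=O)(=O)/C=C/c2ccccc2)cc1`, 1480 nM
compound 2, `COc1ccc(OS(=O)(=O)/C=C/c2ccccc2Cl)cc1`, 237 nM
compound 3, `COc1ccc(OS(=O)(=O)/C=C/c2cccc(Cl)c2)cc1`, 948 nM

Compound 3 holds the second highest of the three numbers: it sits close to compound 1, the step being a 1.6-fold lower number from compound 1 to compound 3 (0.19 log units; within the scatter), and clearly apart from compound 2, the step being a 4.0-fold higher number from compound 2 to compound 3 (0.60 log units; beyond the scatter).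

Compound 4, `COc1ccc(OS(=O)(=O)/C=C/c2ccc(Cl)cc2)cc1`, differs from compound 3 by 4-chlorophenyl in place of 3-chlorophenyl on a double-bonded chain carbon bound to a double-bonded chain carbon. Within the data shown here, no measured step moves the chloro to the 4-chlorophenyl placement. The two chloro steps known, a 6.2-fold lower number from compound 1 to compound 2 (0.80 log units; beyond the scatter) and a 1.6-fold lower number from compound 1 to compound 3 (0.19 log units; within the scatter), show that the number depends strongly on where the chloro sits, one step beyond the scatter and one within it, so neither direction is secured here. The expected step is a 1.4-fold lower number from compound 3 to compound 4 (0.13 log units; within the scatter), with wide uncertainty. Compound 4 is estimated at 700 nM, range 250 nM to 2000 nM.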

Compound 4, half-maximal effective concentration: 1160 nM
Compound 4: the middle estimate sits 1.7-fold (0.22 log units) below what was measured, and the stated range covers the measured number.
By their numbers in this assay, from the lowest: compound 2; then compounds 3, 4 and 1 (each within the scatter of the next).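

In this assay, the 4-chlorophenyl group does not separate from the 3-chlorophenyl group (a 1.2-fold higher number from compound 3 to compound 4 (0.09 log units; within the scatter)), nor from the chloro-free phenyl (a 1.3-fold lower number from compound 1 to compound 4 (0.11 log units; within the scatter)). The 2-chlorophenyl group stands apart (a 4.9-fold higher number from compound 2 to compound 4 (0.69 log units; beyond the scatter)), so among the three chloro placements shown, only 2-chlorophenyl gives a step beyond the scatter from the chloro-free compound.

Open, as far as these compounds go, is whether a methyl or an amine in place of the chloro of 2-chlorophenyl would hold the number of compound 2. Nothing at hand explains why 2-chlorophenyl differs from the other two placements.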